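The compounds below may be only part of what the source reports. "The series", "measured", "known", "first", "only" and "open" are said of these compounds alone.

Compound 2 `C=C1C(=O)[C@]23C[C@@]1(O)CC[C@H]2c1ccc(O)c(C)c1[C@@H]3Cn1cc(-c2ccc(F)cc2)nn1` and compound 1 `C=C1C(=O)[C@]23C[C@@]1(O)CC[C@H]2c1ccc(O)c(C)c1[C@@H]3Cn1cc(-c2ccccn2)nn1` share one core and differ in a single place: pyridin-2-yl in place of 4-fluorophenyl on an aromatic carbon. In a functional assay on HL-60 cells (Homo sapiens) for cytotoxicity, read by MTT assay, with a stated time of 4 days (on this read-out higher numbers stand for weaker inhibition and lower numbers for stronger inhibition), compound 2 gives 660 nM, and compound 1 gives 1970 nM, which is a 3.0-fold higher number from compound 2 to compound 1 (0.47 log units; beyond the scatter). Compound 3 `C=C1C[C@]23C[C@@]1(O)CC[C@H]2c1cc(Br)c(O)c(C)c1[C@@H]3Cn1cc(-c2ccc(F)cc2)nn1` sits on a different core; the difference between the two cores is not broken down here. In this assay compound 3 gives 6600 nM, the highest number of the three. Compound 4 `C=C1C[C@]23C[C@@]1(O)CC[C@H]2c1cc(Br)c(O)c(C)c1[C@@H]3Cn1cc(-c2ccccn2)nn1` is compound 3 carrying the same change, at the same place: pyridin-2-yl in place of 4-fluorophenyl on an aromatic carbon. Going by the values given here, since the same change is the only one between compound 2 and compound 1, the step it produced there is the only guide. The step expected for compound 4 is a 3.0-fold higher number from compound 3 to compound 4 (0.48 log units; beyond the scatter). In this assay compound 4 is therefore estimated at about 20000 nM.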

Compound 4, half-maximal inhibitory concentration: > 20000 nM
Compound 4: a limit, no number; the forecaster's own chance of this, stated with the estimate: 25%; the middle value sits exactly at the limit.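

In this assay compound 4 gives > 20000 nM, which is a limit of the assay and not a number. Putting pyridin-2-yl in place of 4-fluorophenyl on this core therefore gives an at least 3.0-fold higher number from compound 3 to compound 4 (0.48 log units; beyond the scatter), so the change raises the number on both cores shown, and no compound here goes against this. This does not show that the step has the same size on the two cores, and two cores are too few to support a general rule for the series: the same change on two cores in this assay, a 3.0-fold higher number (0.47 log units; beyond the scatter) from compound 2 to compound 1 and an at least 3.0-fold higher number (0.48 log units; beyond the scatter) from compound 3 to compound 4; the limit leaves it open whether they differ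

The compounds shown leave open what a carboxylic acid or an amine in that place would do to the number. They also leave open whether pyridin-2-yl has a similar effect on any further core.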